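The source may hold more compounds than are shown below. What is called first, only, known or untested is meant among the compounds shown, and "the series" means these compounds.

Measured compounds:
- Compound 1 `COc1cc2nc(OC3CCN(C(=O)OC(C)(C)C)CC3)nc(Nc3ccc(S(C)(=O)=O)cc3)c2cc1OC` — in a functional assay on HEK293 cells for agonist activity at Glucose-dependent insulinotropic receptor (Homo sapiens), read by cAMP accumulation, with a stated time of 60 min (a lower number here means that less compound is needed, a higher number that more compound is needed for the effect), compound 1 gives > 10000 nM, which is a limit of the assay and not a number.
- Compound 2 `COc1cc2nc(N3CCC4CCC(C3)N4Cc3ccccc3)nc(Nc3ccc(S(C)(=O)=O)cc3)c2cc1OC` — in this assay compound 2 gives > 10000 nM, again only a limit.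

Among the measured compounds shown here, compound 2 therefore cannot be placed on a scale: both values shown sit at the limit of > 10000 nM in this assay, at which 2 of the 2 values shown sit, and no step between measured compounds can be drawn from them. Compound 3 `COc1cc2nc(N3CCC4CCC(C3)N4C(=O)OC(C)(C)C)nc(Nc3ccc(S(C)(=O)=O)cc3)c2cc1OC` differs from compound 2 in one place: tert-butoxycarbonyl in place of benzyl on an amine nitrogen in a ring. Compound 1 carries the same tert-butoxycarbonyl on a ring amine and likewise reaches only the limit. From this, no step beyond the scatter is expected in this assay in either direction. The expected step is a step that the limit leaves unreadable from compound 2 to compound 3. Compound 3 is estimated at 15000 nM, with a range from 5000 nM to 50000 nM, and most likely only a limit will again be reported.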

Compound 3, half-maximal effective concentration: > 10000 nM
Compound 3 ended at the assay's limit; the forecaster's own chance of this, stated with the estimate: 80%; the middle value lies beyond the limit too.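

Compound 2 and compound 3 both give only a limit and no number, so no step can be read between them: the limit of > 10000 nM in this assay, at which 3 of the 3 values shown sit.

Still open, going by these compounds, is whether benzyl and tert-butoxycarbonyl on this amine nitrogen differ at all, and which change to the shared core would give a readable value.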